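The compounds below may be only part of what the source reports. "The series", "measured", "known", "first", "only" and "open" are said of these compounds alone.

Working notes on the series. Compound 1 `C[C@H](NC(=O)Nc1ccccc1Cl)c1ccccc1` serves as the starting point; in an ADME assay on the whole organism with Oryza sativa as the target, tested at 1 uM (a higher number here means a weaker effect of the compound at the concentration tested, a lower number a stronger effect), compound 1 gives 104%. Compound 3 `C[C@H](NC(=O)Nc1cccc(Cl)c1Cl)c1ccccc1` carries one further change, (chloro in place of hydrogen on an aromatic carbon), and in this assay compound 3 gives 100%; the step of a number 4 percentage points lower from compound 1 to compound 3 (within the scatter) is small. Compound 2 `C[C@@H](NC(=O)Nc1cccc(Cl)c1)c1ccccc1` has the same atoms as compound 1 joined differently; the difference between the two cores is not broken down here. In this assay compound 2 gives 91%, a lower number than compound 1 and one that sits close to compound 3.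

Compound 4 `C[C@@H](NC(=O)Nc1cc(Cl)ccc1Cl)c1ccccc1` is not yet measured. It differs from compound 2 by chloro in place of hydrogen on an aromatic carbon. This is the same kind of change as from compound 1 to compound 3, but the surroundings differ: there the entering chloro was ortho to a chloro group and meta to a large group, here it is ortho to a large group and para to a chloro group. For compound 4 the expected step of a number 2 percentage points lower from compound 2 to compound 4 (within the scatter) rests on the small size of a number 4 percentage points lower from compound 1 to compound 3 (within the scatter), so little movement is expected. Compound 4 is estimated at 89%, expected between 75% and 103%.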

Compound 4, a percentage reported as activity, at one concentration (the size of the read-out at that concentration, not a potency): 100%
The estimate for compound 4 lay 11 percentage points below the measured number; low and high end bracket the measured number.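

In this assay, among these compounds, the entry of a chloro in place of hydrogen on an aromatic carbon gives a number 9 percentage points higher from compound 2 to compound 4 (within the scatter), so on this core as well the change produces no step that stands clear of the scatter. Set beside the earlier case, the two steps cannot be told apart: the same change on two cores in this assay, a number 4 percentage points lower (within the scatter) from compound 1 to compound 3 and a number 9 percentage points higher (within the scatter) from compound 2 to compound 4, 13 percentage points apart, within the scatter of two such steps. This shows that, on these two cores, carrying the change over reveals no measurable dependence on the core; it does not show that the two steps are equal, that a small effect is absent from the scatter, or that the same would hold on any further core or with the chloro ortho to a large group and para to a chloro group on another core.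

Chloro is the only entering group shown, so it stays open whether a methoxy, a nitrile or a trifluoromethyl in the same place would give a step beyond the scatter. Also open, from the compounds shown here alone, is what an amine, a carboxylic acid or a longer chain elsewhere on the shared core would do to the read-out.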